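Replacing the Side-Chain Aryl Group: What to Expect

The source may report more compounds than this note shows. Statements on the series, on what has been measured and on what is new or still open speak of the compounds shown alone.

Compound 1 `CC(C)C[C@H](N)c1cc(C(F)(F)F)ccc1N1CCN(C(=O)C(C)Cc2ccc(Cl)cc2O)CC1` gives 36 nM in an assay on HEK293 cells for displacement of a labelled ligand from Melanocortin receptor 4 (Homo sapiens); on this read-out lower numbers stand for stronger inhibition and higher numbers for weaker inhibition. For the measured compounds named here, compound 2 `COc1ccc(CC(C)C(=O)N2CCN(c3ccc(C(F)(F)F)cc3[C@@H](N)CC(C)C)CC2)cc1` gives 120 nM in this assay and has the higher of the two numbers; the only measured step, a 3.3-fold higher number from compound 1 to compound 2 (0.52 log units; beyond the scatter), changed just the aromatic group on the side chain. Compound 3 `CC(C)C[C@H](N)c1cc(C(F)(F)F)ccc1N1CCN(C(=O)COc2cccc(Cl)c2)CC1` alters that same side chain again: (3-chlorophenoxy)methyl in place of 1-(4-methoxybenzyl)ethyl on a carbonyl carbon. Going by the values given here, only that one step bears on this change, and it was modest, so a step of similar size, in no firm direction, is expected. The expected step in this assay is a 1.5-fold lower number from compound 2 to compound 3 (0.18 log units; within the scatter). Compound 3 is therefore estimated at 80 nM, within 20 nM to 350 nM.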

Compound 3, inhibition constant: 2600 nM
Compound 3: middle estimate off by 33-fold (1.51 log units), on the low side, outside the stated range (above it).
By their numbers in this assay, from the lowest: compound 1; then compound 2; then compound 3.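

In this assay, for the compounds shown here, the (3-chlorophenoxy)methyl group on this carbonyl carbon brings a 22-fold higher number from compound 2 to compound 3 (1.34 log units; beyond the scatter) and a 72-fold higher number from compound 1 to compound 3 (1.86 log units; beyond the scatter) so this place tolerates far less change than the single earlier step suggested. The groups leaving and entering in the step from compound 2 each carry one aromatic ring and one hydrogen-bond acceptor, so those counts alone do not track the loss. Nothing measured here explains it. From the compounds shown here alone, whether the oxygen in the chain or the smaller group matters more stays open, as does how a 2-phenylethyl group would compare.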